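Ring-opened allylic amine in a chemokine receptor antagonist series

This account rests on a few compounds, and the source may have more. Where it says the series, first, only, none or still open, it means among the compounds named here.

Compound 3 `NCC1=C(CN(C[C@H]2Cc3ccccc3CN2)[C@H]2CCCc3cccnc32)CCCC1` gives 230 nM in a functional assay on CCRF-CEM cells for antagonist activity at C-X-C chemokine receptor type 4 (Homo sapiens), read by calcium flux, with stated times of 25 min and 90 s (a higher number here means a weaker inhibitor, a lower number a stronger inhibitor), which places it second highest among the three measured numbers: compound 2 `NC(=O)NC/C=C\CN(C[C@H]1Cc2ccccc2CN1)[C@H]1CCCc2cccnc21` gives 210 nM, a gap of a 1.1-fold higher number from compound 2 to compound 3 (0.04 log units; within the scatter), while compound 1 `C/C(CN(C[C@H]1Cc2ccccc2CN1)[C@H]1CCCc2cccnc21)=C(/F)CN` gives 1800 nM, a gap of a 7.8-fold lower number from compound 1 to compound 3 (0.89 log units; beyond the scatter). Compound 4 `C/C(=C/CN)CN(C[C@H]1Cc2ccccc2CN1)[C@H]1CCCc2cccnc21` differs from compound 3 by a group of 5 heavy atoms (4 carbon, 1 nitrogen; no ring) in place of a group of 8 heavy atoms (7 carbon, 1 nitrogen; one six-membered non-aromatic ring of carbon only), on a saturated chain carbon bound to an amine nitrogen. Within the data shown here, the step that bears most directly on this change is the one from compound 1 to compound 3, where the cyclohexenyl group replaced an acyclic fluorinated chain and gave a 7.8-fold lower number from compound 1 to compound 3 (0.89 log units; beyond the scatter); the change to compound 4 undoes the ring, but the entering group carries no fluorine, so compound 1 is not its exact mirror. Compound 2 offers another acyclic chain with an 8.6-fold lower number from compound 1 to compound 2 (0.93 log units; beyond the scatter) relative to compound 1, showing that open chains need not be weak. An intermediate outcome is therefore expected, with compound 4 estimated at 550 nM (range 180 nM to 1800 nM), a step of a 2.4-fold higher number from compound 3 to compound 4 (0.38 log units; beyond the scatter) expected from compound 3.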

Compound 4, half-maximal inhibitory concentration: 28 nM
Compound 4: middle estimate off by 20-fold (1.29 log units), on the high side, and the stated range ends above it.
By their numbers in this assay, from the lowest: compound 4; then compounds 2 and 3 (each within the scatter of the next); then compound 1.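

In this assay, compounds 2 and 3 had given numbers within the scatter of each other, so an open chain and the 2-(aminomethyl)cyclohex-1-en-1-yl ring could not be told apart at this saturated chain carbon bound to an amine nitrogen, but the group in compound 4 now stands apart from both, with an 8.2-fold lower number from compound 3 to compound 4 (0.91 log units; beyond the scatter) and a 7.5-fold lower number from compound 2 to compound 4 (0.88 log units; beyond the scatter). The largest step, a 64-fold lower number from compound 1 to compound 4 (1.81 log units; beyond the scatter), shows that an open chain without fluorine gives the lowest number of the four, so the ring is not required here and the fluorinated chain of compound 1 is not representative of open chains. No evidence is given that bears on the reason for these steps.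

The compounds shown do not separate the contribution of the chain's methyl branch from that of the urea carbonyl in the step from compound 2. Going by these compounds, whether a longer chain, or a hydroxyl in place of the amine, would keep the number of compound 4 remains open.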